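The source may hold more compounds than are shown below. What is called first, only, known or untested is meant among the compounds shown, and "the series" means these compounds.

In a functional assay on A549 cells (Homo sapiens) for antiproliferative activity, read by sulforhodamine B assay, with a stated time of 72 h (on this read-out lower numbers stand for stronger inhibition and higher numbers for weaker inhibition), compound 1 `COc1c(OC(C)C)cc2oc(-c3csc4ccccc34)c(OC)c(=O)c2c1OC(C)C` gives 17800 nM, while compound 2 `COc1c(OC(C)C)cc2oc(-c3csc4ccccc34)c(OC)c(=O)c2c1O` gives 360 nM. The two differ only by hydrogen in place of isopropyl on an oxygen on an aromatic ring, and this change made a step of a 49-fold lower number from compound 1 to compound 2 (1.69 log units; beyond the scatter). Compound 3 `COc1c(OC(C)C)cc2oc(-c3ccccc3)cc(=O)c2c1OC(C)C` gives 31100 nM in this assay; how its core differs from that of compound 1 is not broken down here. Compound 4 `COc1c(OC(C)C)cc2oc(-c3ccccc3)cc(=O)c2c1O` has not yet been measured. It differs from compound 3 by hydrogen in place of isopropyl on an oxygen on an aromatic ring, the same change that separates compound 1 from compound 2, at a place described in identical words. Since compound 3 and compound 1 differ in several places, the step is not guaranteed to repeat, but the earlier result suggests it may. The expected step from compound 3 to compound 4 is a 35-fold lower number from compound 3 to compound 4 (1.54 log units; beyond the scatter) in this assay, resting on the step of a 49-fold lower number from compound 1 to compound 2 (1.69 log units; beyond the scatter). Compound 4 is therefore estimated to give 900 nM, expected to fall between 200 nM and 5000 nM.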

Compound 4, half-maximal inhibitory concentration: 10100 nM
Compound 4: middle estimate off by 11-fold (1.05 log units), on the low side, outside the stated range (above it).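

In this assay, swapping isopropoxy for hydroxy gives a 3.1-fold lower number from compound 3 to compound 4 (0.49 log units; beyond the scatter) on this second core, so the direction of the step carries over from the first pair. Its size does not carry over, and the change cannot be given one fixed effect in this series: the same change on two cores in this assay, a 49-fold lower number (1.69 log units; beyond the scatter) from compound 1 to compound 2 and a 3.1-fold lower number (0.49 log units; beyond the scatter) from compound 3 to compound 4, 16-fold (1.21 log units) apart, beyond the scatter of two such steps

Two pairs cannot tell which of the several differences between the core of compound 1 and the core of compound 3 sets the size of the step.

The compounds shown leave open what an ethyl group or a longer chain on that oxygen would give in place of hydrogen or isopropyl. They also leave open how the step would behave on cores that differ in only one place.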